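This account rests on a few compounds, and the source may have more. Where it says the series, first, only, none or still open, it means among the compounds named here.

Compound 2 `O=C(NCCCCCc1ccccc1)n1c(=O)oc2ccccc21` stands at the lowest of the two numbers recorded so far: in an assay on HEK293 cells for inhibition of acid ceramidase (Homo sapiens), with a stated time of 10 min (a higher number here means a weaker inhibitor, a lower number a stronger inhibitor), compound 2 gives 54 nM. The nearest is compound 1 `COc1ccc(CCCCNC(=O)n2c(=O)oc3ccccc32)cc1`, which in this assay gives 63 nM; the step of a 1.2-fold lower number from compound 1 to compound 2 (0.07 log units; within the scatter) lies within the scatter of this kind of measurement. Compound 3 `O=C(NCCCCCCc1ccccc1)n1c(=O)oc2ccccc21` has not yet been measured. It differs from compound 2 in one place: benzyl in place of phenyl on a saturated chain carbon, five bonds along the chain from an amide-type nitrogen. For the measured compounds named here, only one measured step bears on this, a 1.2-fold lower number from compound 1 to compound 2 (0.07 log units; within the scatter), which likewise put benzyl at the end of the chain in place of another aryl group and produced no movement beyond the scatter. On that basis no step beyond the scatter is expected for compound 3 in this assay, the expected step being a 1.1-fold lower number from compound 2 to compound 3 (0.03 log units; within the scatter). Compound 3 is therefore estimated at 50 nM, within a range from 20 nM to 130 nM.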

Compound 3, half-maximal inhibitory concentration: 51 nM
Compound 3: middle estimate off by 1.0-fold (0.01 log units), on the low side; the measured number falls inside the stated range.
By their numbers in this assay, from the lowest: compounds 3, 2 and 1 (each within the scatter of the next).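

In this assay, benzyl in place of phenyl on a saturated chain carbon, five bonds along the chain from an amide-type nitrogen, gives a 1.1-fold lower number from compound 2 to compound 3 (0.02 log units; within the scatter), so this lengthening of the chain end does not move the number beyond the scatter. The change at the chain end that removes the 4-methoxyphenyl group gives a 1.2-fold lower number from compound 1 to compound 3 (0.09 log units; within the scatter), so all three pairs among these compounds now lie within the scatter, which the single earlier step could not show. No evidence is at hand that speaks to the reason for this result.

The compounds shown leave open how far this flat stretch runs, whether a longer chain or a shorter chain would hold the number. They also leave open whether an amine or a carboxylic acid at the chain end would do the same.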